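Swapping the amide substituents on a tricyclic amide core

The source may hold more compounds than are shown below. What is called first, only, known or untested is meant among the compounds shown, and "the series" means these compounds.

Four compounds share one core; compound 1 `CCCN(Cc1ccccc1)C(=O)c1c(C)nc2n1CCCN2c1c(C)cc(C)cc1C`, compound 2 `CCCN(CC1CC1)C(=O)c1c(CC)nc2n1CCCN2c1c(C)cc(C)cc1C` and compound 3 `C=CCN(CC=C)C(=O)c1c(C)nc2n1CCC(=O)N2c1c(C)cc(C)cc1C` have been measured, compound 4 `CCCN(CC1CC1)C(=O)c1c(C)nc2n1CCC(=O)N2c1c(C)cc(C)cc1C` has not. In an in vitro assay on IMR-32 cells for displacement of a labelled ligand from corticotropin-releasing factor receptor 1 (Homo sapiens) (a lower number here means a stronger inhibitor, a higher number a weaker inhibitor), compound 2 gives 2300 nM. For compound 1 the assay returns only a limit, > 5000 nM. Compound 3 likewise stands only at a limit, > 5000 nM, so its exact position among the numbers shown is unknown; in this respect it shares (the limit of > 5000 nM in this assay, at which 2 of the 3 values shown sit). The change to compound 4 is (cyclopropylmethyl)(propyl)amino in place of diallylamino on a carbonyl carbon. For the measured compounds named here, no measured pair shows this change alone, and with compound 3 known only as a limit, the step of a number no higher from compound 3 to compound 4 (the limit leaves the size open) is expected to be none beyond the scatter. Compound 4 is therefore estimated at 5000 nM, between 1500 nM and 20000 nM.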

Compound 4, inhibition constant: > 5000 nM
Compound 4: only a limit was reported; the forecaster's own chance of this, stated with the estimate: 50%; the middle value sits exactly at the limit.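

Compound 3 and compound 4 both return only a limit, so the step between them cannot be read: the limit of > 5000 nM in this assay, at which 3 of the 4 values shown sit.

The compounds shown leave open whether (cyclopropylmethyl)(propyl)amino in place of diallylamino changes inhibitor strength at all.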